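The compounds below may be only part of what the source reports. "The series", "measured", "known", "first", "only" and "open" are said of these compounds alone.

Compound 1 `COc1ccc2c(=O)c(/C=C/C(=O)Nc3ccc(Cl)cc3)coc2c1` carries a chloro group on the amide-side aryl ring and a methoxy on the core. In a functional assay on A549 cells (Homo sapiens) for inhibition, read by MTT assay, with a stated time of 48 h (on this read-out higher numbers stand for weaker inhibition and lower numbers for stronger inhibition), compound 1 gives > 100000 nM, which is a limit of the assay rather than a number. The two compounds with a measured number, compound 2 `Cc1ccc(CNC(=O)/C=C/c2coc3cc(O)ccc3c2=O)cc1` and compound 3 `O=C(/C=C/c1coc2cc(O)ccc2c1=O)Nc1ccccc1`, differ from compound 1 in both the core substituent and the amide side; compound 2 gives 17400 nM and compound 3 gives 24400 nM, so that a 1.4-fold higher number from compound 2 to compound 3 (0.15 log units; within the scatter).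

Compound 4 `COc1ccc(NC(=O)/C=C/c2coc3cc(OC)ccc3c2=O)cc1` differs from compound 1 in one place: methoxy in place of chloro on an aromatic carbon. For the measured compounds named here, no measured step covers this change; the only measured step concerns the substituent on the amide-type nitrogen and stays within the scatter.

Compound 4 is therefore expected near 100000 nM, between 30000 nM and 300000 nM, with a number no higher from compound 1 to compound 4 (the limit leaves the size open) expected.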

Compound 4, half-maximal inhibitory concentration: 23000 nM
Beside the measured number, compound 4's estimate is 4.3-fold (0.64 log units) above it; measured number below the stated range.
By their numbers in this assay, from the lowest: compounds 2, 4 and 3 (each within the scatter of the next). At a limit, above all of these: compound 1.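

For the compounds shown here, the 4-chlorophenyl to 4-methoxyphenyl change, para to a large group, had no measured step among the earlier compounds; in this assay this single change gives an at least 4.3-fold lower number from compound 1 to compound 4 (0.63 log units; beyond the scatter). It is the only step shown that lies beyond the scatter, so the read-out does respond to the group at this place, whereas the change on the amide-type nitrogen stayed within the scatter. The value of compound 1 is a limit and not a number, so the true size of this step stays open: the limit of > 100000 nM in this assay, at which 1 of the 4 values shown sits.

The compounds shown leave open whether an amine or a carboxylic acid at this place would give a number like that of compound 4.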